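The source may report more compounds than this note shows. Statements on the series, on what has been measured and on what is new or still open speak of the compounds shown alone.

In a functional assay on MCF7 cells (Homo sapiens) for inhibition, read by MTT assay, with a stated time of 72 h (on this read-out lower numbers stand for stronger inhibition and higher numbers for weaker inhibition), compound 1 `CCc1ccc(NC(=O)C2CCN(C/C=C/c3ccccc3)CC2)cc1` gives 20000 nM and compound 2 `CCCCc1ccc(NC(=O)C2CCN(C/C=C/c3ccccc3)CC2)cc1` gives 5870 nM. Compound 3 `COc1ccc(NC(=O)C2CCN(C/C=C/c3ccccc3)CC2)cc1` stands at > 100000 nM, which is a limit and not a number. Compound 4 `CN1CCN(c2ccc(NC(=O)C3CCN(C/C=C/c4ccccc4)CC3)cc2)CC1` carries 4-methylpiperazin-1-yl in place of methoxy on the aromatic carbon, para to a large group (4-methylpiperazin-1-yl in place of methoxy on an aromatic carbon). For the measured compounds named here, two measured steps concern this place: an at least 5.0-fold higher number from compound 1 to compound 3 (0.69 log units; beyond the scatter) and an at least 17-fold higher number from compound 2 to compound 3 (1.23 log units; beyond the scatter), both beyond the scatter. Read in reverse, they suggest that losing methoxy lowers the number, although neither ethyl nor butyl is a ring. A modest to large fall is therefore expected in this assay, and the estimated step is an at least 6.6-fold lower number from compound 3 to compound 4 (0.82 log units; beyond the scatter). Compound 4 is expected at 15000 nM, with an estimated range from 3000 nM to 80000 nM.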

Compound 4, half-maximal inhibitory concentration: 44000 nM
The estimate for compound 4 lay 2.9-fold (0.47 log units) below the measured number, within the range that was stated.
By their numbers in this assay, from the lowest: compound 2; then compound 1; then compound 4. At a limit, above all of these: compound 3.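

In this assay, 4-methylpiperazin-1-yl puts a ring at this position for the first time among the compounds shown, and the number stays higher than with either chain: a 2.2-fold higher number from compound 1 to compound 4 (0.34 log units; beyond the scatter) and a 7.5-fold higher number from compound 2 to compound 4 (0.87 log units; beyond the scatter). A ring here thus does not match ethyl or butyl, yet the number still falls relative to methoxy, an at least 2.2-fold lower number from compound 3 to compound 4 (0.35 log units; beyond the scatter). That step starts from a limit and not a number: the limit of > 100000 nM in this assay, at which 1 of the 4 values shown sits.

As far as these compounds go, whether a longer chain such as hexyl would lower the number beyond butyl remains open. So does how morpholine or an unsubstituted piperazine would compare with 4-methylpiperazin-1-yl.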